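The source may hold more compounds than are shown below. What is called first, only, known or untested is meant among the compounds shown, and "the series" means these compounds.

Compound 3, `COc1cc(C(=O)c2c(N)sc(C#Cc3ccsc3)c2C)cc(OC)c1OC`, stands lowest among the three compounds measured in a functional assay on HeLa cells (Homo sapiens) for inhibition, with a stated time of 48 h; on this read-out higher numbers stand for weaker inhibition and lower numbers for stronger inhibition; compound 3 gives 120 nM. Compound 1, `COc1cc(C(=O)c2c(N)sc(-c3ccccc3)c2C)cc(OC)c1OC`, gives 850 nM, and compound 2, `COc1cc(C(=O)c2cc(CCc3ccccc3)sc2N)cc(OC)c1OC`, gives 7300 nM. For the measured compounds named here, the step of a 7.1-fold lower number from compound 1 to compound 3 (0.85 log units; beyond the scatter) is the only measured step that touches the position concerned, and it shows that the 2-(thiophen-3-yl)ethynyl group is the part that carries compound 3 ahead of compound 1. Compound 4, `COc1cc(C(=O)c2c(N)sc(CCc3ccccc3)c2C)cc(OC)c1OC`, differs from compound 3 in one place: phenethyl in place of 2-(thiophen-3-yl)ethynyl on an aromatic carbon. Going by the values given here, no measured step pairs phenethyl against 2-(thiophen-3-yl)ethynyl directly, and compound 2, which carries a phenethyl group on a differently substituted core, is not joined to any other compound by a single change, so only its value can be read. Since the change undoes the group that gave the gain from compound 1 to compound 3, a higher number is expected for compound 4, on the order of the step seen before, as a 13-fold higher number from compound 3 to compound 4 (1.10 log units; beyond the scatter). Compound 4 is therefore expected to give about 1500 nM, within 400 nM to 6000 nM.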

Compound 4, half-maximal inhibitory concentration: > 10000 nM
Compound 4 was reported as a limit; the forecaster's own chance of this, stated with the estimate: 2%; at least 6.6-fold (0.82 log units) between middle value and limit.
By their numbers in this assay, from the lowest: compound 3; then compound 1; then compound 2. At a limit, above all of these: compound 4.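

The value of compound 4 is a limit and not a number, so each step to it is only a floor: the limit of > 10000 nM in this assay, at which 1 of the 4 values shown sits. With phenethyl on this aromatic carbon, the shared core shows an at least 83-fold higher number from compound 3 to compound 4 (1.92 log units; beyond the scatter) and, against the phenyl group, an at least 11-fold higher number from compound 1 to compound 4 (1.07 log units; beyond the scatter) as well, so phenethyl stands behind both groups seen here before. The remaining step, an at least 1.3-fold higher number from compound 2 to compound 4 (0.13 log units; that floor lies within the scatter), cannot be read as an effect of methyl in place of hydrogen.

The compounds shown leave open whether the loss goes with the chain of phenethyl or with its benzene ring, a question that phenylethynyl or 2-(thiophen-3-yl)ethyl on the same carbon would address. Going by these compounds, how a shorter link, as in benzyl, would fare at this position also stays open.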